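A few compounds are considered here, and "the series" means these few. Any claim that something is new, unique, unknown or untested is made for them only; others in the source may bear on it.

Two compounds have been measured in an assay on isolated protein for inhibition of bone morphogenetic protein 1 (Homo sapiens); a higher number here means a weaker inhibitor, a lower number a stronger inhibitor:

Compound 1 `COc1ccc(S(=O)(=O)N(Cc2cc(C)on2)[C@H](C)C(=O)NO)cc1` gives 230 nM
Compound 2 `COc1ccc(S(=O)(=O)N(Cc2sc3scc(C)c3c2C)[C@H](C)C(=O)NO)cc1` gives 60 nM

Both share the same core, a hydroxamic acid joined through a sulfonamide to a methoxyphenyl ring. Of the two numbers, compound 1 has the higher one, and its gap to compound 2 lies beyond the usual scatter of this assay; the two differ in more than one place, so the numbers alone are what they show.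

Compound 3 `COc1ccc(S(=O)(=O)N(Cc2cc(F)cc(F)c2)[C@H](C)C(=O)NO)cc1` has not yet been measured. It differs from compound 1 by 3,5-difluorophenyl in place of 5-methyl-1,2-oxazol-3-yl on a saturated chain carbon bound to a sulfonamide nitrogen. Going by the values given here, no measured pair isolates this change, so any expectation rests only on the two numbers above. The step of a 1.8-fold lower number from compound 1 to compound 3 (0.25 log units; within the scatter) is expected to be modest, toward a lower number, and close to the scatter. Compound 3 is therefore estimated at 130 nM, with a range from 40 nM to 450 nM.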

Compound 3, half-maximal inhibitory concentration: 140 nM
For compound 3 the middle estimate is 1.1-fold (0.03 log units) below the measured one, and the stated range covers the measured number.
By their numbers in this assay, from the lowest: compound 2; then compounds 3 and 1 (each within the scatter of the next).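

In this assay, going by these compounds alone, putting 3,5-difluorophenyl in place of 5-methyl-1,2-oxazol-3-yl on a saturated chain carbon bound to a sulfonamide nitrogen gives a 1.6-fold lower number from compound 1 to compound 3 (0.22 log units; within the scatter), the first comparison here in which only one place differs. In this one pair, a five-membered aromatic ring with 2 hetero atoms and 2 hydrogen-bond acceptors gives way to a six-membered ring of carbon only with 0 hydrogen-bond acceptors, and the numbers stay within the scatter of each other, so these acceptors are not needed to keep the number in this range. Nothing at hand explains why this exchange leaves the numbers so close.

On these data alone, whether a plain phenyl ring, without the two fluorines, would give a number close to that of compound 3 stays open. So does the outcome of placing a carboxylic acid or an amine at this position.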